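Hydroxy in place of dimethylamino on the chain of compound 3

The compounds below may be only part of what the source reports. "The series", "measured", "known", "first", "only" and "open" are said of these compounds alone.

Compound 3 `CN(C)CC[C@@H]1C[C@@H](c2ccc(Cl)c(Cl)c2)[C@H](NC(=O)c2cc(-c3c(Cl)cnn3C)c(Cl)o2)CN1` gives 3.4 nM in an assay for inhibition of RAC-alpha serine/threonine-protein kinase (Homo sapiens), read by HTRF, with a stated time of 1 h (a lower number here means a stronger inhibitor, a higher number a weaker inhibitor), the second highest of three numbers. Compound 2 `Cn1ncc(Cl)c1-c1cc(C(=O)N[C@@H]2CN[C@H](CC(N)=O)C[C@H]2c2ccc(Cl)c(Cl)c2)oc1Cl` gives 3.24 nM, and compound 1 `Cn1ncc(Cl)c1-c1cc(C(=O)N[C@@H]2CN[C@H](CCN3CCCCC3)C[C@H]2c2ccc(Cl)c(Cl)c2)oc1Cl` gives 5.65 nM; the steps of a 1.0-fold higher number from compound 2 to compound 3 (0.02 log units; within the scatter) and a 1.7-fold lower number from compound 1 to compound 3 (0.22 log units; within the scatter) both lie within the scatter, as does a 1.7-fold lower number from compound 1 to compound 2 (0.24 log units; within the scatter). Compound 4 `Cn1ncc(Cl)c1-c1cc(C(=O)N[C@@H]2CN[C@H](CCO)C[C@H]2c2ccc(Cl)c(Cl)c2)oc1Cl` carries hydroxy in place of dimethylamino on a saturated chain carbon, two bonds along the chain from a saturated ring carbon. Of the measured steps, a 1.7-fold lower number from compound 1 to compound 3 (0.22 log units; within the scatter) changes the same place and was flat; the chain swaps in a 1.7-fold lower number from compound 1 to compound 2 (0.24 log units; within the scatter) and a 1.0-fold higher number from compound 2 to compound 3 (0.02 log units; within the scatter) were also flat. No step beyond the scatter is therefore expected for compound 4 in this assay. Compound 4 is estimated at 4 nM, with a range from 1.5 nM to 12 nM. The expected step of a 1.2-fold higher number from compound 3 to compound 4 (0.07 log units; within the scatter) stays within the scatter.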

Compound 4, half-maximal inhibitory concentration: 2.74 nM
Compound 4: the middle estimate sits 1.5-fold (0.16 log units) above what was measured; the measured number falls inside the stated range.
By their numbers in this assay, from the lowest: compounds 4, 2, 3 and 1 (each within the scatter of the next, the first and the last beyond it).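

Hydroxy on a saturated chain carbon, two bonds along the chain from a saturated ring carbon, stands level with dimethylamino in this assay (a 1.2-fold lower number from compound 3 to compound 4 (0.09 log units; within the scatter)), and hydroxymethyl stands level with carbamoyl (a 1.2-fold lower number from compound 2 to compound 4 (0.07 log units; within the scatter)), so an amine at the chain end is not needed for numbers of this size. Against piperidin-1-yl, the change gives the first step in the series beyond the scatter, though a modest one (a 2.1-fold lower number from compound 1 to compound 4 (0.31 log units; beyond the scatter)). No measurement at hand accounts for these steps.

Open, from the compounds shown here alone, is how a carboxylic acid or a methyl ether at this place would read. Going by these compounds, a longer chain ending in hydroxy is also open.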